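Selenium-bearing fused cores and growth inhibition in HT-29 cells

A few compounds are considered here, and "the series" means these few. Any claim that something is new, unique, unknown or untested is made for them only; others in the source may bear on it.

Measured so far:
compound 1 `CCCCC[Se]c1nc(NCc2ccc(SC)cc2)c2ccccc2n1` — 83600 nM
compound 2 `CSc1ccc(CNc2nc([SeH])nc3ccccc23)cc1` — 42900 nM
compound 3 `Nc1nc([SeH])nc2ncccc12` — 36300 nM

The read-out throughout is a functional assay on HT-29 cells (Homo sapiens) for cytotoxicity, read by MTT assay, with a stated time of 72 h; a lower number here means a stronger inhibitor of growth, a higher number a weaker inhibitor of growth. In this assay compound 1 gives 83600 nM, compound 2 gives 42900 nM and compound 3 gives 36300 nM. All three numbers lie in the same broad region; compound 3 and compound 2 sit within the scatter of each other, while compound 1 and compound 3 are separated by a gap that is beyond it.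

One change is seen twice in the set. From compound 2 to compound 1 it is pentyl in place of hydrogen on a selenium, and the measured step is a 1.9-fold higher number from compound 2 to compound 1 (0.29 log units; within the scatter). From compound 3 to compound 4 `CCCCC[Se]c1nc(N)c2cccnc2n1` the change is pentyl in place of hydrogen on a selenium; the place given for both is worded the same, so this is the same change made on a different core. How the core of compound 3 differs from that of compound 2 is not broken down here.

Among the compounds with values here, with only one measured example of the change, the expectation for compound 4 rests on that single step. Compound 4 is expected to move from compound 3 by a 1.9-fold higher number from compound 3 to compound 4 (0.28 log units; within the scatter), because the same change gave a 1.9-fold higher number from compound 2 to compound 1 (0.29 log units; within the scatter). The estimate for compound 4 in this assay is 69000 nM, with a range of 30000 nM to 160000 nM to allow for the different core and the scatter of such measurements.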

Compound 4, concentration for 50% growth inhibition: 5910 nM
Compound 4: middle estimate off by 12-fold (1.07 log units), on the high side; measured number outside the range, below it.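

In this assay, pentyl in place of hydrogen on a selenium gives a 6.1-fold lower number from compound 3 to compound 4 (0.79 log units; beyond the scatter), whereas on the other core the same change gives a 1.9-fold higher number from compound 2 to compound 1 (0.29 log units; within the scatter), a step that stays within the scatter. The size of this step therefore does not carry from one core to the other in this series: the same change on two cores in this assay, a 1.9-fold higher number (0.29 log units; within the scatter) from compound 2 to compound 1 and a 6.1-fold lower number (0.79 log units; beyond the scatter) from compound 3 to compound 4, 12-fold (1.08 log units) apart, beyond the scatter of two such steps

Within the data shown here, this does not show which difference between the two cores goes with the different outcome, and with only two pairs it sets no rule for any further core, so the step seen on the core of compound 3 cannot be assumed elsewhere, and no pattern can be claimed for pentyl on selenium as such.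

The compounds shown leave open how a shorter chain such as ethyl, a longer chain such as octyl, or a benzyl group on the selenium would behave on either core. They also leave open whether the large step belongs to pentyl alone, and whether a further core carrying the free amine, or a carboxylic acid at the end of the chain, would follow compound 4 or compound 1.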